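Lengthening the ethoxy chain of compound 2

The compounds below may be only part of what the source reports. "The series", "measured", "known", "first", "only" and "open" are said of these compounds alone.

So far an ADME assay on Jurkat cells (Homo sapiens) for cytotoxicity, read by MTT assay, with a stated time of 72 h (a higher number here means a weaker inhibitor, a lower number a stronger inhibitor), has been run on two compounds that share one core. Compound 1 `CCNC(=O)c1cnc(Oc2ccc3c(c2)B(O)OC3)cn1` gives 79900 nM and compound 2 `CCOC(=O)c1cnc(Oc2ccc3c(c2)B(O)OC3)cn1` gives 16800 nM as the lower of the two numbers. Going by the values given here, the one measured step is a 4.8-fold lower number from compound 1 to compound 2 (0.68 log units; beyond the scatter) with ethoxy in place of ethylamino on a carbonyl carbon. Compound 3 `CC(C)COC(=O)c1cnc(Oc2ccc3c(c2)B(O)OC3)cn1` differs from compound 2 in one place, where isopropyl in place of methyl on a saturated chain carbon bound to an oxygen next to a carbonyl group turns ethoxy into isobutoxy. The measured step bears only loosely on this one: it changed the group on the carbonyl carbon, whereas here only the chain changes. Among the compounds with values here, no measured pair varies the chain, so the expectation stays anchored on compound 2 at 16800 nM in this assay with no clear move in either direction. The expected step is a 1.2-fold lower number from compound 2 to compound 3 (0.08 log units; within the scatter) in size, an estimate that leaves the direction open. For compound 3 the estimated value is 14000 nM with a likely range of 6000 nM to 33000 nM around it.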

Compound 3, half-maximal inhibitory concentration: 17600 nM
Compound 3: middle estimate off by 1.3-fold (0.10 log units), on the low side; the measured number falls inside the stated range.
By their numbers in this assay, from the lowest: compounds 2 and 3 (each within the scatter of the next); then compound 1.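

Going from ethoxy to isobutoxy in this assay gives a 1.0-fold higher number from compound 2 to compound 3 (0.02 log units; within the scatter) and so leaves these two chains indistinguishable in this read-out, something the earlier pair could not show, since it varied only the group on the carbonyl carbon. The gap to the ethylamino compound also survives the new chain: a 4.5-fold lower number from compound 1 to compound 3 (0.66 log units; beyond the scatter) is similar in size to a 4.8-fold lower number from compound 1 to compound 2 (0.68 log units; beyond the scatter) and so, among these three compounds, the lower numbers go with ethoxy and isobutoxy, and no compound here goes against that. No supporting measurement is available to account for either observation.

Only two chains have been compared at this place, so the result says nothing yet about a much longer chain such as octyl, a ring-bearing group such as benzyl, or a free carboxylic acid on the carbonyl carbon. As far as these compounds go, it also remains open whether isobutylamino on the carbonyl carbon would differ from ethylamino, which would show whether chains make as little difference on the nitrogen-linked side as they do on the oxygen-linked side.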